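A few compounds are considered here, and "the series" means these few. Any claim that something is new, unique, unknown or untested is made for them only; others in the source may bear on it.

Measured so far in a functional assay on IGROV-1 cells (Homo sapiens) for inhibition, read by sulforhodamine B assay, with a stated time of 48 h (on this read-out lower numbers stand for stronger inhibition of growth and higher numbers for weaker inhibition of growth), are three compounds: compound 1 `CC(=O)/C(=C\c1c(-c2ccccc2)[nH]c2ccccc12)S(=O)(=O)c1ccccc1` gives 1500 nM, compound 2 `COc1ccc2[nH]c(-c3ccccc3)c(/C=C(\C#N)S(=O)(=O)c3ccccc3)c2c1` gives 4800 nM, and compound 3 `N#C/C(=C\c1c(-c2ccccc2)[nH]c2ccccc12)S(=O)(=O)c1ccccc1` gives 3300 nM.

Compound 3 holds the second highest of the three numbers. Two single changes lead to it. One is a 1.5-fold lower number from compound 2 to compound 3 (0.16 log units; within the scatter), where hydrogen stands in place of methoxy on an aromatic carbon. The other is a 2.2-fold higher number from compound 1 to compound 3 (0.34 log units; beyond the scatter), where a nitrile takes the place of the acetyl group.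

Compound 4 `N#C/C(=C\c1c(-c2ccccc2)[nH]c2ccccc12)C(=O)c1ccccc1` has not been measured. It differs from compound 3 in a single place: benzoyl in place of phenylsulfonyl on a double-bonded chain carbon bound to a double-bonded chain carbon and a triple-bonded carbon. Among the compounds with values here, neither measured step touches this group, so no direct precedent exists. Within the data shown here, the only measured step that swaps a carbonyl against another group, the one from compound 1 to compound 3, was modest, which suggests that this kind of change at the chain does not move the number far. A modest shift in either direction is possible, but the data give no direction.

Compound 4 is therefore expected to give about 3000 nM in this assay, with a range from 1000 nM to 10000 nM. This estimate means a 1.1-fold lower number from compound 3 to compound 4 (0.04 log units; within the scatter), expected to stay within the scatter.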

Compound 4, concentration for 50% growth inhibition: 2500 nM
For compound 4 the middle estimate is 1.2-fold (0.08 log units) above the measured one; measured number inside the range.
By their numbers in this assay, from the lowest: compounds 1, 4, 3 and 2 (each within the scatter of the next, the first and the last beyond it).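

In this assay, a 1.3-fold lower number from compound 3 to compound 4 (0.12 log units; within the scatter), the first step shown at this place, with benzoyl in place of phenylsulfonyl on a double-bonded chain carbon bound to a double-bonded chain carbon and a triple-bonded carbon. The earlier compounds shown here all carried phenylsulfonyl here, so they could not show whether the sulfonyl sulfur is needed; with the nitrile present, compound 4 holds a number within the scatter of compound 3 without any sulfur in this group. Nothing at hand explains why these two groups can be exchanged in this way.

This single pair says nothing about how benzoyl would fare with acetyl in place of the nitrile, or with methoxy on the aromatic carbon that carries it in compound 2. It also leaves open what a carboxylic acid, an amide or a plain alkyl chain would do at this place, so the tolerance seen here cannot yet be called general for the series.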